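Swapping a thiophene for a pyridine on the amide side chain

A few compounds are considered here, and "the series" means these few. Any claim that something is new, unique, unknown or untested is made for them only; others in the source may bear on it.

Measured so far:
- compound 1 `O=C(Cn1c(=O)oc2cc([N+](=O)[O-])ccc21)Nc1ccccn1`: 38.6%
- compound 2 `O=C(Cn1c(=O)oc2ccccc21)NCc1ccccn1`: 37.3%
- compound 3 `O=C(Cn1c(=O)oc2cc([N+](=O)[O-])ccc21)NCc1cccs1`: 36.6%

All three values come from an ADME assay on RAW264.7 cells (Mus musculus) for cytotoxicity, read by MTT assay, with a stated time of 72 h, tested at 50 uM; on this read-out higher numbers stand for a stronger effect at the one concentration tested and lower numbers for a weaker effect. Compound 3 gives the lowest of the three numbers, but its gaps to compound 2 and to compound 1 both lie within the usual scatter, so the three compounds cannot be told apart on this read-out.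

Compound 4 `O=C(Cn1c(=O)oc2cc([N+](=O)[O-])ccc21)NCc1ccccn1` has not yet been measured. It differs from compound 3 in one place: pyridin-2-yl in place of thiophen-2-yl on a saturated chain carbon bound to an amide-type nitrogen. Among the measured compounds shown here, the only measured step that touches this part of the molecule is a number 2 percentage points lower from compound 1 to compound 3 (within the scatter), which shows that exchanging the aromatic group on the amide nitrogen, even together with the extra chain carbon, did not move the number beyond the scatter. Compound 2, which carries the same (pyridin-2-yl)methyl group as compound 4 but lacks the nitro group, sits in the same narrow band in this assay.

On this basis the change to compound 4 is expected to give a number 1.4 percentage points higher from compound 3 to compound 4 (within the scatter), no step beyond the scatter. The estimated value for compound 4 in this assay is 38%, with an expected range from 30% to 46%.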

Compound 4, a percentage reported as inhibition, at one concentration (the size of the read-out at that concentration, not a potency): 21.8%
Beside the measured number, compound 4's estimate is 16.2 percentage points above it; the whole stated range lies above it.
By their numbers in this assay, from the lowest: compound 4; then compounds 3, 2 and 1 (each within the scatter of the next).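

In this assay, the group on the saturated chain carbon bound to an amide-type nitrogen turns out to matter: pyridin-2-yl in place of thiophen-2-yl gives a number 14.8 percentage points lower from compound 3 to compound 4 (beyond the scatter) and marks a real difference, which the closely grouped earlier compounds did not reveal. The other two single changes leading to compound 4 also count, with nitro in place of hydrogen on an aromatic carbon giving a number 15.5 percentage points lower from compound 2 to compound 4 (beyond the scatter) and (pyridin-2-yl)methyl in place of pyridin-2-yl on an amide-type nitrogen giving a number 16.8 percentage points lower from compound 1 to compound 4 (beyond the scatter), so among these compounds the lower number appears only where the nitro group and the (pyridin-2-yl)methyl group occur together. No supporting data offer an explanation for this drop.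

Going by these compounds, it remains open whether an amine in place of the nitro group would give the same low number. A phenyl ring in place of the pyridin-2-yl ring also remains untested among the compounds shown.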